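Acetyl to Ethyl on the Aniline Ring: Expected Inhibition

A few compounds are considered here, and "the series" means these few. Any claim that something is new, unique, unknown or untested is made for them only; others in the source may bear on it.

Compound 3 `CC(=O)c1ccc(Nc2cccc3c2C(=O)N(C2CCC(=O)NC2=O)C3=O)cc1` gives the lowest of the three numbers in an assay on FRT-Jurkat cells for inhibition of nuclear factor NF-kappa-B complex (Homo sapiens), read by flow cytometry, with a stated time of 24 h, tested at 10 uM (on this read-out lower numbers stand for less inhibition and higher numbers for more inhibition at the one concentration tested (going by the name of the read-out)), at 2%. Compound 1 `COc1ccc(Nc2cccc3c2C(=O)N(C2CCC(=O)NC2=O)C3=O)cc1` gives 13% and compound 2 `C=C(OCC)c1ccc(Nc2cccc3c2C(=O)N(C2CCC(=O)NC2=O)C3=O)cc1` gives 10%. The step of a number 11 percentage points lower from compound 1 to compound 3 (beyond the scatter) lies beyond the scatter, whereas the step of a number 8 percentage points lower from compound 2 to compound 3 (within the scatter) and the step of a number 3 percentage points lower from compound 1 to compound 2 (within the scatter) both lie within it. Compound 4 `CCc1ccc(Nc2cccc3c2C(=O)N(C2CCC(=O)NC2=O)C3=O)cc1` differs from compound 3 by ethyl in place of acetyl on an aromatic carbon. Among the compounds with values here, the steps that bear on this are the two into compound 3, where acetyl replaced methoxy or 1-ethoxyethenyl on an aromatic carbon and the number fell modestly or within scatter. Within the data shown here, no measured step covers ethyl, so compound 4 is expected to show only a small rise a number 5 percentage points higher from compound 3 to compound 4 (within the scatter), probably within scatter. The estimate for compound 4 is 7%, ranging from 0% to 18%.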

Compound 4, a percentage reported as inhibition, at one concentration (the size of the read-out at that concentration, not a potency): 17%
Compound 4: the middle estimate sits 10 percentage points below what was measured; measured number inside the range.
By their numbers in this assay, from the lowest: compounds 3, 2, 1 and 4 (each within the scatter of the next, the first and the last beyond it).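

In this assay, replacing acetyl with ethyl on the aromatic carbon para to a large group gives a second step out of compound 3 that lies beyond the scatter: a number 15 percentage points higher from compound 3 to compound 4 (beyond the scatter). Ethyl, by contrast, stays level with the other two groups: a number 7 percentage points higher from compound 2 to compound 4 (within the scatter) and a number 4 percentage points higher from compound 1 to compound 4 (within the scatter). No available evidence explains the difference between acetyl and ethyl. Open, as far as these compounds go, is whether a longer alkyl chain, an amine or a carboxylic acid at this position would take the number clear of the other four compounds. Also open is how any of these compounds behaves at other concentrations.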